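Removing a Benzyl Group from a Hydroxamic Acid Series

The source may hold more compounds than are shown below. What is called first, only, known or untested is meant among the compounds shown, and "the series" means these compounds.

Of the compounds shown here, two of this set share a core and have been measured in a physicochemical assay for lipophilicity; on this read-out higher numbers stand for higher lipophilicity and lower numbers for lower lipophilicity. Compound 1, `O=C(NC1(C(=O)NO)CCCCC1)c1ccc(C#Cc2ccccc2)cc1`, carries a saturated ring of carbon atoms. In this assay compound 1 gives > 3, which is a limit of the assay rather than a number. Compound 2, `O=C(NC1(C(=O)NO)CCN(Cc2ccccc2)CC1)c1ccc(C#Cc2ccccc2)cc1`, carries a ring nitrogen that bears a benzyl group. In this assay compound 2 gives > 3, again a limit rather than a number. Within the data shown here, compound 2 thus stands at the limit, as does every value recorded so far, (the limit of > 3 in this assay, at which 2 of the 2 values shown sit), and no step between measured compounds can be drawn from these two readings.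

Compound 3, `O=C(NC1(C(=O)NO)CCNCC1)c1ccc(C#Cc2ccccc2)cc1`, has not yet been measured. It differs from compound 2 in one place: hydrogen in place of benzyl on an amine nitrogen in a ring. Among the measured compounds shown here, since compound 2 sits at a limit, no measured step guides the expectation, and the change is judged from the structures alone. A drop in this assay beyond the usual scatter is expected. The expected move is a number at least 2.00 log units lower from compound 2 to compound 3 (beyond the scatter). Compound 3 is estimated at 1, within 0 to 2.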

Compound 3, distribution coefficient: 3
The estimate for compound 3 lay 2.00 log units below the measured number, outside the stated range (above it).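

Among these compounds, with hydrogen on the amine nitrogen in a ring, compound 3 gives 3 in this assay, the only true number among the values shown, so this position can hold a group that brings the reading onto the scale. Swapping benzyl for hydrogen at this place gives a number no higher from compound 2 to compound 3 (the limit leaves the size open), which fixes a direction of no rise but leaves open whether the step is small or large. The size of this step stays unknown because compound 2 carries a limit and not a number: the limit of > 3 in this assay, at which 2 of the 3 values shown sit.

As far as these compounds go, whether a methyl group or an acetyl group on the same ring nitrogen would give a number like that of compound 3, or a limit like that of compound 2, stays open. So does the reading with a longer chain ending in a carboxylic acid at this place, which would show how the scale responds to a group quite unlike benzyl or hydrogen.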